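Fluorine on the distal phenyl of an acid ceramidase inhibitor

The source may hold more compounds than are shown below. What is called first, only, known or untested is meant among the compounds shown, and "the series" means these compounds.

Compound 1 `O=C(NCCCCc1ccccc1)n1c(=O)oc2ccccc21`: 64 nM
Compound 2 `Cc1ccc2c(c1)oc(=O)n2C(=O)NCCCCc1ccccc1`: 66 nM

In an assay on HEK293 cells for inhibition of acid ceramidase (Homo sapiens), with a stated time of 10 min (on this read-out higher numbers stand for weaker inhibition and lower numbers for stronger inhibition), compound 1 gives 64 nM, the lower of the two numbers measured, though the gap to compound 2 is small: the step of a 1.0-fold higher number from compound 1 to compound 2 (0.01 log units; within the scatter), a methyl in place of hydrogen on an aromatic carbon of the shared core, lies within the scatter. Among the compounds with values here, compound 3 `O=C(NCCCCc1ccc(F)cc1)n1c(=O)oc2ccccc21` differs from compound 1 by fluoro in place of hydrogen on an aromatic carbon; the change sits on the six-membered aromatic ring of carbon only at the end of the chain, far from the site of the one measured step. Within the data shown here, that step, the only comparison available, was flat. Among the measured compounds shown here, no measured step touches this ring, so the expectation rests on the flat behaviour of the series so far: the author expects compound 3 to stay close to compound 1, with a step of a 1.1-fold lower number from compound 1 to compound 3 (0.03 log units; within the scatter) and an estimated value of 60 nM, between 25 nM and 150 nM.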

Compound 3, half-maximal inhibitory concentration: 75 nM
Beside the measured number, compound 3's estimate is 1.3-fold (0.10 log units) below it; the range from low to high includes it.
By their numbers in this assay, from the lowest: compounds 1, 2 and 3 (each within the scatter of the next).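

Fluoro in place of hydrogen on the ring at the end of the chain, para to a large group, gives a 1.2-fold higher number from compound 1 to compound 3 (0.07 log units; within the scatter) in this assay. Within the data shown here, the earlier step touched only the shared core, so this is the first reading from the far end of the molecule: a single fluorine at this place on the phenyl ring is tolerated, with no difference that can be told from the scatter. No available evidence bears on the reason for this result.

Going by these compounds, one small atom says little about how much room this position allows, so it remains open whether chloro, methoxy or trifluoromethyl would be tolerated there as well. An amine or a carboxylic acid on this ring, or a longer chain leading to it, could also behave quite differently.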